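The compounds below may be only part of what the source reports. "The series", "measured", "known", "first", "only" and "open" are said of these compounds alone.

Measured compounds:
compound 1, `COc1ccc(OC)c(Nc2cc(NC(=O)Nc3c(Cl)cccc3Cl)ncn2)c1`, with 81.7%
compound 2, `COc1cc(Br)ccc1Nc1cc(NC(=O)Nc2c(Cl)cccc2Cl)ncn1`, with 43%

Two compounds sharing one core have been run through a functional assay on NCI-H226 cells (Homo sapiens) for inhibition, read by MTT assay, with a stated time of 48 h, tested at 10 uM; on this read-out higher numbers stand for more inhibition at the one concentration tested (going by the name of the read-out) and lower numbers for less inhibition. Compound 1, `COc1ccc(OC)c(Nc2cc(NC(=O)Nc3c(Cl)cccc3Cl)ncn2)c1`, gives 81.7% in this assay. Compound 2, `COc1cc(Br)ccc1Nc1cc(NC(=O)Nc2c(Cl)cccc2Cl)ncn1`, gives 43% in this assay, which places it lowest of the two numbers; the gap up to compound 1 lies beyond the scatter of this kind of measurement. Among the compounds with values here, no step between these two has been worked out in structural terms, so what they show is only their two values.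

Compound 3, `Cc1ccc(Nc2cc(NC(=O)Nc3c(Cl)cccc3Cl)ncn2)cc1F`, is the next compound to be tested. Compared with compound 2 it carries one change: 3-fluoro-4-methylphenyl in place of 4-bromo-2-methoxyphenyl on a nitrogen on an aromatic ring.

Within the data shown here, with no comparable step among the measured pairs to lean on, the size of the change from compound 2 to compound 3 is open. The account expects a modest rise, a number 12 percentage points higher from compound 2 to compound 3 (beyond the scatter), but the range is wide in both directions, and a value within the scatter of compound 2 would not surprise. Compound 3 is estimated at 55%, with a likely span from 20% to 85%.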

Compound 3, a percentage reported as inhibition, at one concentration (the size of the read-out at that concentration, not a potency): 40.7%
For compound 3 the middle estimate is 14.3 percentage points above the measured one; low and high end bracket the measured number.
By their numbers in this assay, from the lowest: compounds 3 and 2 (each within the scatter of the next); then compound 1.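

In this assay, within the data shown here, putting 3-fluoro-4-methylphenyl in place of 4-bromo-2-methoxyphenyl on a nitrogen on an aromatic ring gives a number 2.3 percentage points lower from compound 2 to compound 3 (within the scatter), the first step at this position that can be read. It shows that this exchange, in which the bromine and the oxygen of the leaving group go and a fluorine enters, leaves no difference that can be told from the scatter, so the two different substituent sets on the ring read alike here, and neither compound 2 nor compound 3 comes near compound 1, at 81.7%. Nothing on hand explains why these two groups read alike or why the value of compound 1 stands apart from them.

The compounds shown leave open what this position would give with an amine or a carboxylic acid on the aromatic ring, or with a longer chain in place of the methyl. They also leave open which feature of the group in compound 1 goes with its higher number, since a single reading at one concentration in one cell line cannot separate those features.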